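Aryl swap on an amidine nitrogen in a cytotoxicity assay

This account rests on a few compounds, and the source may have more. Where it says the series, first, only, none or still open, it means among the compounds named here.

Measured in an ADME assay on HEK293 cells (Homo sapiens) for cytotoxicity, read by MTT assay, with a stated time of 48 h; on this read-out lower numbers stand for stronger inhibition and higher numbers for weaker inhibition:
compound 1 `Cc1ccc(S(=O)(=O)/N=C(/CCNC2=CC(=O)c3ccccc3C2=O)Nc2cccc(C)c2)cc1`: 56200 nM
compound 2 `COc1ccc(N/C(CCNC2=CC(=O)c3ccccc3C2=O)=N\S(=O)(=O)c2ccc(C)cc2)cc1OC`: 60600 nM

Compound 2 stands at the higher of the two numbers, with compound 1 the nearest; the step of a 1.1-fold higher number from compound 1 to compound 2 (0.03 log units; within the scatter) falls within the scatter. Compound 3 `Cc1ccc(S(=O)(=O)/N=C(/CCNC2=CC(=O)c3ccccc3C2=O)Nc2cc(F)c(F)c(F)c2)cc1` differs from compound 2 in one place: 3,4,5-trifluorophenyl in place of 3,4-dimethoxyphenyl on an amine nitrogen. Among the measured compounds shown here, no measured step covers this exact change. For the measured compounds named here, the only step in hand, a 1.1-fold higher number from compound 1 to compound 2 (0.03 log units; within the scatter), also exchanged one aryl group for another on the same nitrogen and left the number essentially where it was. With nothing else to go on, no step beyond the scatter is expected for compound 3 in this assay. Compound 3 is therefore estimated at 58000 nM, with a range from 25000 nM to 135000 nM. The expected step, a 1.0-fold lower number from compound 2 to compound 3 (0.02 log units; within the scatter), is small and within the scatter.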

Compound 3, half-maximal inhibitory concentration: 82600 nM
For compound 3 the middle estimate is 1.4-fold (0.15 log units) below the measured one; the range from low to high includes it.
By their numbers in this assay, from the lowest: compounds 1, 2 and 3 (each within the scatter of the next).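

In this assay, the exchange of 3,4-dimethoxyphenyl for 3,4,5-trifluorophenyl on this amine nitrogen gives a 1.4-fold higher number from compound 2 to compound 3 (0.13 log units; within the scatter), so even an aryl group carrying only fluorine as its substituents does not take the number beyond the scatter. The exchange of 3-methylphenyl for the same group gives a 1.5-fold higher number from compound 1 to compound 3 (0.17 log units; within the scatter), also within the scatter, and the three aryl groups shown on this nitrogen therefore cannot be told apart on this read-out. No evidence is available that bears on this result.

From the compounds shown here alone, whether this nitrogen needs an aryl group at all remains open, since a cyclohexyl ring, a longer alkyl chain or a plain hydrogen could behave differently here. Going by these compounds, it is also open whether an aryl group bearing a carboxylic acid or an amine would stay within the scatter.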